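The compounds below may be only part of what the source reports. "The series", "measured", "known", "first", "only" and "open" are said of these compounds alone.

Measured compounds in a functional assay for inhibition, with Homo sapiens as the target; a higher number here means a weaker inhibitor, a lower number a stronger inhibitor:
- compound 1, `CCCc1nc(C)c2cnnc(O)n12`, gives 56800 nM
- compound 2, `Cc1nc(C(C)C)n2c(O)nncc12`, gives > 48000 nM, a limit of the assay and not a number
- compound 3, `CCc1nc(C)c2cnnc(O)n12`, gives > 48000 nM, likewise a limit of the assay and not a number

Compound 3 thus stands at the edge of what this assay resolves; the same holds for compound 2, so the series is characterised by the limit of > 48000 nM in this assay, at which 2 of the 3 values shown sit. Only compound 1 returns a number, and it sits close to that limit.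

The next step replaces (tert-butyl in place of methyl on a saturated chain carbon bound to an aromatic carbon), giving compound 4, `Cc1nc(CC(C)(C)C)n2c(O)nncc12`. The measured steps that touch compound 3 are a step that the limit leaves unreadable from compound 1 to compound 3 and a step that the two limits leave unreadable from compound 2 to compound 3, and the remaining pair gives a step that the limit leaves unreadable from compound 1 to compound 2; none of them has a readable size, so no direction can be taken from them. Changes of the alkyl group on the same carbon have so far left every value at or near the limit.

Compound 4 is therefore expected to remain weak, estimated at 60000 nM with a range of 20000 nM to 200000 nM. The expected step that the limit leaves unreadable from compound 3 to compound 4 is most likely to be reported again only as a limit.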

Compound 4, half-maximal inhibitory concentration: > 48000 nM
Compound 4 gave a limit, no number (the forecaster's own chance of this, stated with the estimate: 65%); the middle value is on the limit's open side.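

Compound 4 adds no readable step: in this assay its result is a limit, so its steps to compound 1, compound 2 and compound 3 cannot be read. The compounds shown leave open whether any change of the alkyl group shifts the value, and in which direction: the limit of > 48000 nM in this assay, at which 3 of the 4 values shown sit.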